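A few compounds are considered here, and "the series" means these few. Any claim that something is new, unique, unknown or untested is made for them only; others in the source may bear on it.

Values in a functional assay on HeLa cells (Homo sapiens) for inhibition, read by trypan blue exclusion, with a stated time of 72 h; a lower number here means a stronger inhibitor of growth, a higher number a weaker inhibitor of growth:

Compound 1 `CC/C(=C(/c1ccc(NC(=O)C(C)C)cc1)c1ccc(OC)cc1)c1ccc(O)cc1` gives 5800 nM
Compound 2 `CC/C(=C(/c1ccccc1)c1ccc(NC(=O)C(C)C)cc1)c1ccccc1` gives 28100 nM
Compound 3 `CC/C(=C(\c1ccc(NC(=O)C(C)C)cc1)c1ccc(OC)cc1)c1ccc(O)cc1` gives 3700 nM

In this assay compound 3 at 3700 nM cannot be told apart from compound 1 at 5800 nM, and compound 2 at 28100 nM has a clearly higher number than either.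

Compound 4 `CC/C(=C(/c1ccccc1)c1ccc(NC(=O)C(C)C)cc1)c1ccc(O)cc1` comes from compound 3 by a single change, (hydrogen in place of methoxy on an aromatic carbon), which is hydrogen in place of methoxy on an aromatic carbon. Within the data shown here, no measured step makes this change directly. Among the measured compounds shown here, the only step available, a 1.6-fold lower number from compound 1 to compound 3 (0.20 log units; within the scatter), concerns configuration alone and suggests that the drawn geometry of the double bond need not weigh much here. For the measured compounds named here, the one hint on the group comes from compound 2, which also carries no methoxy and stands at 28100 nM. A modest rise in this assay is therefore expected, though it may not clear the scatter. The expected change is a 1.9-fold higher number from compound 3 to compound 4 (0.28 log units; within the scatter). For compound 4 the estimate is 7000 nM, with an expected range from 3000 nM to 17000 nM.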

Compound 4, concentration for 50% growth inhibition: 5100 nM
For compound 4 the middle estimate is 1.4-fold (0.14 log units) above the measured one; measured number inside the range.
By their numbers in this assay, from the lowest: compounds 3, 4 and 1 (each within the scatter of the next); then compound 2.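

In this assay the methoxy is not needed at this position, para to a large group: the change to hydrogen gives a 1.4-fold higher number from compound 3 to compound 4 (0.14 log units; within the scatter) and leaves the number within the scatter. The hydroxy is a different matter, since hydroxy in place of hydrogen on an aromatic carbon gives a 5.5-fold lower number from compound 2 to compound 4 (0.74 log units; beyond the scatter) and so ties the high number of compound 2 to the missing hydroxy, not to the missing methoxy. Nothing measured here gives a reason for either step.

The compounds shown leave open whether this position would tolerate anything larger or different from methoxy, such as an ethoxy, an amine or a carboxylic acid. They also leave open whether compound 4 would match its double-bond isomer, as compound 1 and compound 3 do.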